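The source may report more compounds than this note shows. Statements on the series, on what has been measured and on what is new or still open speak of the compounds shown alone.

Measured so far in an assay on isolated protein for inhibition of Polyunsaturated fatty acid 5-lipoxygenase (Homo sapiens); a lower number here means a stronger inhibitor, a higher number a weaker inhibitor:
compound 1, `CCc1cccc(N2CCCC(=O)N2)c1`: 3000 nM
compound 2, `O=C1CCCN(c2cccc(Br)c2)N1`: 1800 nM
compound 3, `CC(=O)c1cccc(N2CCCC(=O)N2)c1`: 19000 nM

Compound 3 holds the highest of the three numbers in this assay. Its nearest neighbour is compound 1 and its furthest is compound 2, the two gaps being a 6.3-fold higher number from compound 1 to compound 3 (0.80 log units; beyond the scatter) and an 11-fold higher number from compound 2 to compound 3 (1.02 log units; beyond the scatter), both beyond the scatter. Between the two smaller substituents the difference is slight: a 1.7-fold lower number from compound 1 to compound 2 (0.22 log units; within the scatter).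

Compound 4, `O=C1CCCN(c2cccc(F)c2)N1`, differs from compound 3 by fluoro in place of acetyl on an aromatic carbon. Among the measured compounds shown here, the steps that bear on this change are the two in which acetyl replaced a small substituent, read in reverse: a 6.3-fold higher number from compound 1 to compound 3 (0.80 log units; beyond the scatter) and an 11-fold higher number from compound 2 to compound 3 (1.02 log units; beyond the scatter). Both point the same way, and since bromo and ethyl sit within the scatter of each other, a third small substituent is expected to land near them. The expected step is therefore a clearly lower number, a 7.6-fold lower number from compound 3 to compound 4 (0.88 log units; beyond the scatter). For compound 4 the estimate in this assay is 2500 nM, with a range from 1000 nM to 6500 nM.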

Compound 4, half-maximal inhibitory concentration: 5500 nM
Compound 4: the middle estimate sits 2.2-fold (0.34 log units) below what was measured; low and high end bracket the measured number.
By their numbers in this assay, from the lowest: compounds 2, 1 and 4 (each within the scatter of the next, the first and the last beyond it); then compound 3.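

In this assay, fluoro in place of acetyl gives a real but partial recovery (a 3.5-fold lower number from compound 3 to compound 4 (0.54 log units; beyond the scatter)), so acetyl keeps the highest number of the four compounds. The substituents that replace acetyl do not form one tight group: fluoro stands apart from bromo (a 3.1-fold higher number from compound 2 to compound 4 (0.49 log units; beyond the scatter)) but not from ethyl (a 1.8-fold higher number from compound 1 to compound 4 (0.26 log units; within the scatter)). Moving away from acetyl at this aromatic carbon is therefore not enough in itself to match bromo, and the choice among the non-acetyl substituents still shifts the number beyond the scatter in the case of fluoro and bromo.

On these data alone, whether chloro, a methoxy group or an amine at this aromatic carbon would fall with bromo, with fluoro or with acetyl stays open. No supporting data bear on the reason for this order.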